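The source may hold more compounds than are shown below. What is called first, only, known or untested is meant among the compounds shown, and "the series" means these compounds.

In a functional assay on CLL cells (Homo sapiens) for cytotoxicity, read by MTT assay, with a stated time of 48 h (a higher number here means that more compound is needed for the effect, a lower number that less compound is needed), compound 1 (`C=C(CC)C(=O)c1ccc(OCC(=O)Nc2ccc(S(=O)(=O)O)cc2)c(Cl)c1Cl`) gives > 25000 nM, which is a limit of the assay and not a number. Compound 2 (`C=C(CC)C(=O)c1ccc(OCC(=O)NC2CCN(CC(=O)OC)CC2)c(Cl)c1Cl`), with a different group on the amide, reaches a measured value of 10600 nM. Compound 3 (`C=C(CC)C(=O)c1ccc(OCC(=O)Nc2ccc(CC(=O)O)cc2)c(Cl)c1Cl`) keeps the core of compound 1 and changes one group: carboxymethyl in place of sulfo on an aromatic carbon, para to a large group (carboxymethyl in place of sulfo on an aromatic carbon). Among the compounds with values here, no pair of measured compounds shows what this swap does in this assay, so only a small shift towards less compound needed is expected. Within the data shown here, the one measured number, from compound 2 at 10600 nM, suggests the likely region. The estimated step is an at least 1.2-fold lower number from compound 1 to compound 3 (0.09 log units; that floor lies within the scatter). For compound 3 the expected value is 20000 nM, with an estimated range of 8000 nM to 40000 nM.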

Compound 3, half-maximal effective concentration: 3200 nM
For compound 3 the middle estimate is 6.3-fold (0.80 log units) above the measured one; the measured number lies below the stated range.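

In this assay compound 1 gives > 25000 nM as a limit of the assay and not a number. Carboxymethyl in place of sulfo on an aromatic carbon, para to a large group, brings an at least 7.8-fold lower number from compound 1 to compound 3 (0.89 log units; beyond the scatter), so the group held at this place clearly matters for this cytotoxicity, even though both groups count the same number of heavy atoms. As far as these compounds go, this step is only a floor and its full size stays unknown, because one end of the pair rests on a limit: the limit of > 25000 nM in this assay, at which 1 of the 3 values shown sits.

The compounds shown leave open whether an amine, or a longer chain ending in a carboxylic acid, at this same place would lower the number further. This single pair also cannot tell which part of the swap carries the step, or whether the step would hold with another group on the amide.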